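The compounds below may be only part of what the source reports. "The series", "measured", "known", "first", "only" and "open" are said of these compounds alone.

The compounds measured in a functional assay on SV5A8 cells (Homo sapiens) for cytotoxicity (on this read-out lower numbers stand for stronger inhibition and higher numbers for weaker inhibition), and what each gave:

Compound 1 `Cc1ccc2c(NCc3ccc(NC(=O)C4CCN(Cc5cccc(F)c5)CC4)cc3)nc(N(C)C)nc2c1`: in this assay compound 1 gives only a limit, > 4170 nM.
Compound 2 `Cc1ccc2c(NCc3ccc(NC(=O)C4CCN(Cc5ccccc5F)CC4)cc3)nc(N(C)C)nc2c1`: in this assay compound 2 gives only a limit, > 6670 nM.
Compound 3 `Cc1ccc2c(NCc3ccc(NC(=O)C4CCN(CC(C)C)CC4)cc3)nc(N(C)C)nc2c1`: in this assay compound 3 gives only a limit, > 10500 nM.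

Compound 3 thus stands nowhere firm: its value is a limit, and the two other values are limits as well. The steps a step that the two limits leave unreadable from compound 1 to compound 3 and a step that the two limits leave unreadable from compound 2 to compound 3 cannot be read, nor can a step that the two limits leave unreadable from compound 1 to compound 2; each runs from one limit to another, as the limit of > 10500 nM in this assay, at which 1 of the 3 values shown sits, the limit of > 4170 nM in this assay, at which 1 of the 3 values shown sits, and the limit of > 6670 nM in this assay, at which 1 of the 3 values shown sits, show.

Compound 4 `Cc1ccc2c(NCc3ccc(NC(=O)C4CCN(C5CCCCC5)CC4)cc3)nc(N(C)C)nc2c1` differs from compound 3 by cyclohexyl in place of isobutyl on an amine nitrogen in a ring. For the measured compounds named here, no measured step bears on this change with a readable size, and the three measured compounds all sit at limits. The expectation is therefore that compound 4 in this assay again shows no measurable inhibition, with an estimated step of an at least 1.0-fold lower number from compound 3 to compound 4 (0.02 log units; that floor lies within the scatter). Compound 4 is estimated at 10000 nM, within 3000 nM to 30000 nM.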

Compound 4, half-maximal inhibitory concentration: > 8320 nM
Compound 4 was reported as a limit (the forecaster's own chance of this, stated with the estimate: 85%); the middle value is on the limit's open side.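

In this assay, for the compounds shown here, compound 4 gives only a limit, > 8320 nM, so, as all four values are limits, no step from compound 1, compound 2 or compound 3 to compound 4 can be read. The compounds shown leave open whether the group on the amine nitrogen in a ring changes the inhibition at all.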